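The source may report more compounds than this note shows. Statements on the series, on what has been measured and on what is new or still open speak of the compounds shown alone.

Series values in an ADME assay on microsomes from liver (Canis lupus familiaris) for metabolic stability, read by LC-MS, using NADPH, with a stated time of 10 min, tested at 0.1 uM; on this read-out lower numbers stand for slow clearance and higher numbers for fast clearance:
compound 1 `Cc1cccc(N2C(=O)CSC2c2cccc(C(=O)NCCCCc3ccccc3)c2)c1`: 749 mL.min-1.g-1
compound 2 `O=C(NCCCCc1ccccc1)c1cccc(C2SCC(=O)N2c2ccccn2)c1`: 492 mL.min-1.g-1
compound 3 `O=C(NCCCCc1ccccc1)c1cccc(C2SCC(=O)N2c2cccc(F)c2)c1`: 837 mL.min-1.g-1

Compound 3, at 837 mL.min-1.g-1, lies within the scatter of both compound 1 and compound 2, so the three numbers form a single group of values. The next compound to be measured is compound 4 `O=C(NCCCCc1ccccc1)c1cccc(C2SCC(=O)N2c2ccccc2F)c1`. Its change is 2-fluorophenyl in place of 3-fluorophenyl on an amide-type nitrogen in a ring, with the same atoms joined differently.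

For the measured compounds named here, no measured step moves the fluoro group around the ring, so the evidence is indirect. Going by the values given here, three steps bear on this position: a 1.1-fold higher number from compound 1 to compound 3 (0.05 log units; within the scatter), a 1.7-fold higher number from compound 2 to compound 3 (0.23 log units; within the scatter) and a 1.5-fold lower number from compound 1 to compound 2 (0.18 log units; within the scatter). All three are small, and none gives a direction to carry forward. The expected change is a 1.2-fold lower number from compound 3 to compound 4 (0.08 log units; within the scatter), and no step beyond the scatter is expected in this assay. For compound 4 the estimated value is 700 mL.min-1.g-1, with an expected range of 400 mL.min-1.g-1 to 1200 mL.min-1.g-1.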

Compound 4, intrinsic clearance in microsomes: 815 mL.min-1.g-1
Compound 4: middle estimate off by 1.2-fold (0.07 log units), on the low side, and the stated range covers the measured number.
By their numbers in this assay, from the lowest: compounds 2, 1, 4 and 3 (each within the scatter of the next).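

In this assay, for the compounds shown here, moving the fluoro group gives the first direct reading at this position (a 1.0-fold lower number from compound 3 to compound 4 (0.01 log units; within the scatter)): 2-fluorophenyl and 3-fluorophenyl on the amide-type nitrogen cannot be told apart. The comparisons with the other two groups stay equally flat (a 1.7-fold higher number from compound 2 to compound 4 (0.22 log units; within the scatter); a 1.1-fold higher number from compound 1 to compound 4 (0.04 log units; within the scatter)), so 2-fluorophenyl joins 3-fluorophenyl, 3-methylphenyl and pyridin-2-yl in a single group of values with no order among them. No measurement shown accounts for how closely these values sit together.

Still open, on these data alone, is whether any change at this nitrogen can move intrinsic clearance beyond the scatter. A carboxylic acid or a morpholine on the phenyl ring would probe that directly, and a shorter chain in place of the phenylbutyl chain on the amide would probe the other end of the series.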